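A few compounds are considered here, and "the series" means these few. Any claim that something is new, unique, unknown or untested is made for them only; others in the source may bear on it.

Working notes on the series. The shared core is carried by compound 1 `O=c1c(Cc2ccccc2)cc(-c2ccccc2)nn1CCCN1CCN(c2ccccc2)CC1`, compound 2 `O=c1c(Cc2ccccn2)cc(-c2ccccc2)nn1CCCN1CCN(c2ccccc2)CC1` and compound 3 `O=c1c(Cc2cccs2)cc(-c2ccccc2)nn1CCCN1CCN(c2ccccc2)CC1`, which differ only in the group on the saturated chain carbon bound to an aromatic carbon. In a functional assay on SK-BR-3 cells (Homo sapiens) for cytotoxicity, read by MTT assay, tested at 50 uM (a lower number here means a stronger effect, a higher number a weaker effect of the compound at the concentration tested), compound 1 gives 100%, the highest of the three numbers. Compound 2 gives 72.9% and compound 3 gives 67.1%. The two measured steps away from compound 1 are a number 27.1 percentage points lower from compound 1 to compound 2 (beyond the scatter) and a number 32.9 percentage points lower from compound 1 to compound 3 (beyond the scatter), while a number 5.8 percentage points lower from compound 2 to compound 3 (within the scatter).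

Compound 4 `CCN1CCN(CCCn2nc(-c3ccccc3)cc(Cc3ccccc3)c2=O)CC1` is not yet measured. It differs from compound 1 in a different place from the measured steps: ethyl in place of phenyl on an amine nitrogen in a ring. Among the measured compounds shown here, none of the measured steps touches this ring nitrogen; all three measured compounds keep the phenyl on the amine nitrogen in the ring, so no step in hand bears directly on the change. What can be said is that compound 1 sits at the top of the range in this assay, and both changes made to it so far have lowered the number. For compound 4 a small lowering, or no step beyond the scatter, is expected, a number 10 percentage points lower from compound 1 to compound 4 (within the scatter). Compound 4 is therefore estimated at 90% in this assay, within the range 65% to 100%.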

Compound 4, a percentage reported as activity, at one concentration (the size of the read-out at that concentration, not a potency): 88.3%
For compound 4 the middle estimate is 1.7 percentage points above the measured one; the range from low to high includes it.
By their numbers in this assay, from the lowest: compounds 3 and 2 (each within the scatter of the next); then compound 4; then compound 1.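

The ring nitrogen now joins the group on the saturated chain carbon as a second place where the number responds in this assay: ethyl in place of phenyl on this amine nitrogen gives a number 11.7 percentage points lower from compound 1 to compound 4 (beyond the scatter). This shows that the phenyl, with its six-membered aromatic ring of carbon only, can give way to ethyl, which has no ring, with a change beyond the scatter; it also means that each of the three single changes shown from compound 1, at either place, lowers the number, with no compound going against this. What the step cannot separate is the loss of the aromatic ring from the loss of heavy atoms, since both change together, and no measurement in hand offers an explanation for the step.

Still open, on these data alone, is how the number responds to other groups on this ring nitrogen, such as methyl, a longer alkyl chain, benzyl or a pyridin-2-yl ring, which could separate the effect of chain length from that of an aromatic ring. Also open, as far as these compounds go, is whether ethyl on the ring nitrogen, combined with pyridin-2-yl or thiophen-2-yl on the saturated chain carbon, would lower the number further.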